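The source may report more compounds than this note shows. Statements on the series, on what has been measured and on what is new or still open speak of the compounds shown alone.

Compound 1 `O=C(O)c1cccc(CNc2cc(C(F)(F)F)cc3[nH]ncc23)c1` is one of two compounds examined in an assay for inhibition of Indoleamine 2,3-dioxygenase 1 (Homo sapiens), with stated times of 10 min and 60 min; on this read-out higher numbers stand for weaker inhibition and lower numbers for stronger inhibition. In this assay compound 1 gives > 100000 nM, which is a limit of the assay rather than a number. Compound 2 `CC(C)n1ncc2c(NCc3ccccc3[N+](=O)[O-])cc(C(F)(F)F)cc21` is the other. In this assay compound 2 gives > 100000 nM, again a limit. Among the compounds with values here, the only evidence is the limit of > 100000 nM in this assay, at which 2 of the 2 values shown sit, so compound 1 stands level with the one other value shown. Compound 3 `FC(F)(F)c1cc(NCc2cccc(Br)c2)c2cn[nH]c2c1` differs from compound 1 in one place, bromo in place of carboxy on an aromatic carbon. Within the data shown here, with no measured step to lean on, no change beyond the scatter is expected in this assay, and the step estimated is a number no higher from compound 1 to compound 3 (the limit leaves the size open). Compound 3 is therefore expected to give 100000 nM, within 20000 nM to 300000 nM, most likely once more as a limit only.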

Compound 3, half-maximal inhibitory concentration: > 100000 nM
Compound 3 was reported as a limit (the forecaster's own chance of this, stated with the estimate: 70%); the middle value sits exactly at the limit.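

Within the data shown here, compound 1 and compound 3 both stand only as limits in this assay, so no step between them can be read. The compounds shown leave open how bromo and carboxy compare on this aromatic carbon.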